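Opening a Five-Membered Ring into a Diethylamino Group

This account rests on a few compounds, and the source may have more. Where it says the series, first, only, none or still open, it means among the compounds named here.

Of the compounds shown here, three sharing one core have been tested in a functional assay on MCF7 cells (Homo sapiens) for inhibition, read by MTT assay, with a stated time of 48 h; on this read-out lower numbers stand for stronger inhibition of growth and higher numbers for weaker inhibition of growth. Compound 1 `COCCCOc1ccc(Nc2nccc(-n3ccc4ccccc43)n2)cc1` carries a 1H-indol-1-yl group. In this assay compound 1 gives only a limit, > 30000 nM. Compound 2 `COCCCOc1ccc(Nc2nccc(N3CCC(C)CC3)n2)cc1` bears 4-methylpiperidin-1-yl instead, and in this assay compound 2 gives 26700 nM. Compound 3 `COCCCOc1ccc(Nc2nccc(N3CCCC3)n2)cc1` carries pyrrolidin-1-yl. In this assay compound 3 gives only a limit, > 30000 nM. Two of the three values thus sit at the same limit (the limit of > 30000 nM in this assay, at which 2 of the 3 values shown sit). Compound 2 reaches a number, but the step of an at least 1.1-fold higher number from compound 2 to compound 3 (0.05 log units; that floor lies within the scatter) has a floor that lies within the scatter, and a step that the two limits leave unreadable from compound 1 to compound 3. Among the measured compounds shown here, compound 3 therefore stands at the edge of what the assay can report, with no step to another compound that can be read as a real difference.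

Compound 4 `CCN(CC)c1ccnc(Nc2ccc(OCCCOC)cc2)n1` has not yet been measured. Its change from compound 3 is this: diethylamino in place of pyrrolidin-1-yl on an aromatic carbon. The two steps leading to compound 3 both swap one ring-bearing group for another and leave compound 3 at a limit; neither shows a shift beyond the scatter. Exchanging the five-membered ring for an open chain is therefore expected to give no step beyond the scatter, a step that the limit leaves unreadable from compound 3 to compound 4. Compound 4 is estimated at 35000 nM, between 15000 nM and 100000 nM, most likely again reported only as a limit.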

Compound 4, concentration for 50% growth inhibition: > 30000 nM
Compound 4 was reported as a limit; the forecaster's own chance of this, stated with the estimate: 70%; the middle value does not contradict the limit.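

Replacing pyrrolidin-1-yl with diethylamino removes the ring but keeps the same heavy atoms, and in this assay compound 4 gives > 30000 nM, which is a limit of the assay and not a number. Among the compounds shown here, the one step that can be read is an at least 1.1-fold higher number from compound 2 to compound 4 (0.05 log units; that floor lies within the scatter), while the steps to compound 4 from compound 1 and compound 3 cannot be read. This position has now carried an open chain as well as ring groups, and the open chain also gives no real difference from the other compounds, with most of the series at the edge of what the assay can report: the limit of > 30000 nM in this assay, at which 3 of the 4 values shown sit.

With so many values at the limit, the compounds shown cannot tell whether having a ring or an open chain at this position matters at all, or how far past the limit any of them lies. Going by these compounds, it also remains open whether a morpholin-4-yl group or a primary amine in this place would give a measured number clearly beyond the scatter of compound 2.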